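Aryl swap at the alkene carbon: compound 1 to compound 4

The source may report more compounds than this note shows. Statements on the series, on what has been measured and on what is new or still open speak of the compounds shown alone.

Measured so far:
compound 1, `O=C(O)CCCC/C=C(/c1ccc(Br)cc1)c1cccnc1`: 82 nM
compound 2, `CCOC(=O)CCCC/C=C(\c1ccccc1)c1cccnc1`: 600 nM
compound 3, `O=C(O)C(CCC/C=C(\c1ccccc1)c1cccnc1)Sc1ccccc1`: 33 nM

All three values come from an assay (Equus caballus) for inhibition of Thromboxane-A synthase (Homo sapiens), using microsomes; a lower number here means a stronger inhibitor, a higher number a weaker inhibitor. Compound 1 stands second highest of the three numbers. Compound 3 gives the nearest value, a lower number that lies beyond the scatter; compound 2 gives the furthest value, a higher number, also beyond the scatter. For the measured compounds named here, neither compound 2 nor compound 3 differs from compound 1 in one place only, so no single step between measured compounds is on record.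

Compound 4, `O=C(O)CCCC/C=C(\c1cccnc1)c1ccsc1`, has yet to be measured in this assay. It differs from compound 1 in one place:
thiophen-3-yl in place of 4-bromophenyl on a double-bonded chain carbon bound to an aromatic carbon and a double-bonded chain carbon
Going by the values given here, no measured pair shows this change, so the size of the step rests on judgement alone. With the shared core and the acid chain kept, the expectation is a step of no more than the scatter, in either direction; the estimated step is a 1.0-fold lower number from compound 1 to compound 4 (0.01 log units; within the scatter). For compound 4 the estimate in this assay is 80 nM, with an expected range from 30 nM to 250 nM.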

Compound 4, half-maximal inhibitory concentration: 31 nM
Beside the measured number, compound 4's estimate is 2.6-fold (0.41 log units) above it; measured number inside the range.
By their numbers in this assay, from the lowest: compounds 4 and 3 (each within the scatter of the next); then compound 1; then compound 2.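

In this assay, the position on a double-bonded chain carbon bound to an aromatic carbon and a double-bonded chain carbon now has its first single-place reading, with a 2.6-fold lower number from compound 1 to compound 4 (0.42 log units; beyond the scatter) as a modest step beyond the scatter. The earlier compounds shown here could not show that this position responds to a change of aryl group, nor that thiophen-3-yl, a five-membered aromatic ring, can stand in place of 4-bromophenyl with the acid chain kept. No measurement at hand bears on the reason for this step.

The compounds shown do not separate the loss of the bromine from the change of ring, and a 4-chlorophenyl or a thiophen-2-yl at this position would bear on that. As far as these compounds go, it also stays open whether the step carries over to other chains, such as the ethyl ester chain of compound 2.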